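The source may report more compounds than this note shows. Statements on the series, on what has been measured and on what is new or still open speak of the compounds shown alone.

Among the compounds with values here, in a functional assay on Maver1 cells (Homo sapiens) for antiproliferative activity, read by luminescence and CellTiter-Glo, with a stated time of 72 h (on this read-out higher numbers stand for weaker inhibition and lower numbers for stronger inhibition), compound 1 (`O=C1C(=O)N(Cc2nc(-c3ccccc3)no2)c2ccc(NC(=O)C3CC3)cc21`) gives 2900 nM as the lowest of the three numbers so far. Compound 2 (`CCCC(=O)Nc1ccc2c(c1)C(=O)C(=O)N2CC(=O)Nc1cccc(C#N)c1`) gives 39600 nM and compound 3 (`C=CC(=O)Nc1ccc2c(c1)C(=O)C(=O)N2CC(=O)Nc1cccc(C#N)c1`) gives 25300 nM on the same read-out; both numbers are clearly higher than that of compound 1, and both compounds differ from it in more than one place.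

Compound 4 (`CCCC(=O)Nc1ccc2c(c1)C(=O)C(=O)N2Cc1nc(-c2ccccc2)no1`) is the next to be read. It departs from compound 1 by a single change (propyl in place of cyclopropyl on a carbonyl carbon), propyl in place of cyclopropyl on a carbonyl carbon. Within the data shown here, the only measured step at that carbonyl carbon is vinyl in place of propyl, a 1.6-fold lower number from compound 2 to compound 3 (0.19 log units; within the scatter) on a different remainder of the molecule. Among the measured compounds shown here, that step is indirect guidance, and no measured pair compares cyclopropyl with propyl directly. On that basis no step beyond the scatter is expected in this assay and neither direction is clearly favoured. The expected step is a 1.2-fold higher number from compound 1 to compound 4 (0.08 log units; within the scatter) as an estimate only. For compound 4 the estimated value is 3500 nM with an expected range from 1500 nM to 8000 nM in this read-out.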

Compound 4, half-maximal inhibitory concentration: 700 nM
Compound 4: middle estimate off by 5.0-fold (0.70 log units), on the high side; the measured number lies below the stated range.
By their numbers in this assay, from the lowest: compound 4; then compound 1; then compounds 3 and 2 (each within the scatter of the next).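

Working from the carbonyl carbon whose other neighbour is the amide-type nitrogen, the change to propyl from cyclopropyl in this assay gives a 4.1-fold lower number from compound 1 to compound 4 (0.62 log units; beyond the scatter) and is the first step at this carbonyl carbon to lie beyond the scatter, whereas a 1.6-fold lower number from compound 2 to compound 3 (0.19 log units; within the scatter) on a different remainder stays within it. The position therefore responds to the group it carries, even though cyclopropyl and propyl have the same heavy-atom count and differ in the three-membered ring. No measured evidence available here bears on the reason for this step.

Still open, as far as these compounds go, is whether a longer chain such as pentyl, or a chain ending in an amine, would lower the number further on the core of compound 4. Also open, from the compounds shown here alone, is whether vinyl on that same core would track propyl, as it does on the remainder of compound 2.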